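Swapping a Sulfonyl Group for a Benzyl Group

The source may hold more compounds than are shown below. What is called first, only, known or untested is meant among the compounds shown, and "the series" means these compounds.

Compound 3 `CCN(CC)c1ccc2cc(C(=O)c3ccc(N4CCN(C(=O)CN5CCN(S(=O)(=O)c6ccc(F)cc6)CC5)CC4)cc3)oc2c1` was tested in a functional assay on A549 cells (Homo sapiens) for cytotoxicity, read by MTT assay, with a stated time of 48 h (on this read-out higher numbers stand for weaker inhibition and lower numbers for stronger inhibition), where compound 3 gives 33200 nM. Among the numbers shown, compound 3 stands highest; compound 1 `CCN(CC)c1ccc2cc(C(=O)c3ccc(N4CCN(C(=O)CN5CCN(C(=O)/C=C/c6ccccc6)CC5)CC4)cc3)oc2c1` gives 9450 nM, the step being a 3.5-fold higher number from compound 1 to compound 3 (0.55 log units; beyond the scatter). Compound 2 `CCN(CC)c1ccc2cc(C(=O)c3ccc(N4CCN(C(=O)CN5CCN(S(=O)(=O)c6ccc(OC(F)(F)F)cc6)CC5)CC4)cc3)oc2c1` reaches only a limit of the assay, > 40000 nM, namely (the limit of > 40000 nM in this assay, at which 1 of the 3 values shown sits). The step of an at least 1.2-fold lower number from compound 2 to compound 3 (0.08 log units; that floor lies within the scatter) lies within the scatter. Compound 4 `CCN(CC)c1ccc2cc(C(=O)c3ccc(N4CCN(C(=O)CN5CCN(Cc6ccc(C(F)(F)F)cc6)CC5)CC4)cc3)oc2c1` differs from compound 3 by 4-(trifluoromethyl)benzyl in place of (4-fluorophenyl)sulfonyl on an amine nitrogen in a ring. Of the measured steps, only the earlier change at the same ring nitrogen, a 3.5-fold higher number from compound 1 to compound 3 (0.55 log units; beyond the scatter), bears on this one, and it was modest; the change on the aromatic ring stayed within the scatter. A modest move towards a lower number is therefore expected, a 2.2-fold lower number from compound 3 to compound 4 (0.35 log units; beyond the scatter). Compound 4 is estimated at 15000 nM, between 5000 nM and 45000 nM.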

Compound 4, half-maximal inhibitory concentration: 20100 nM
The estimate for compound 4 lay 1.3-fold (0.13 log units) below the measured number, within the range that was stated.
By their numbers in this assay, from the lowest: compound 1; then compounds 4 and 3 (each within the scatter of the next). At a limit, above all of these: compound 2.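

At this ring nitrogen, in this assay, the step of a 1.7-fold lower number from compound 3 to compound 4 (0.22 log units; within the scatter) shows that 4-(trifluoromethyl)benzyl can take the place of (4-fluorophenyl)sulfonyl without a clear shift, even though the entering group has no hydrogen-bond acceptors. The (2-phenylethenyl)carbonyl group keeps its edge over this benzyl group, with a 2.1-fold higher number from compound 1 to compound 4 (0.33 log units; beyond the scatter) as the step, a modest one.

As far as these compounds go, whether a benzyl ring carrying a carboxylic acid or an amine would read differently stays open. Nothing measured here explains these differences.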